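Swapping Fluorine Positions on a Shared Core

The compounds below may be only part of what the source reports. "The series", "measured", "known", "first", "only" and "open" are said of these compounds alone.

Compound 1 `CC(C)(C)Cc1c(-c2ccccn2)sc(N)c1C(=O)c1ccc(Cl)cc1` and compound 2 `CC(C)(C)Cc1c(-c2ccc(F)cc2F)sc(N)c1C(=O)c1ccc(Cl)cc1` share a core and differ only in one aryl group. In an assay on CHO cells for displacement of a labelled ligand from adenosine receptor A3 (Homo sapiens), read by scintillation counting, tested at 10 uM (on this read-out higher numbers stand for more inhibition at the one concentration tested (going by the name of the read-out) and lower numbers for less inhibition), compound 1 gives 1%, and in this assay compound 2 gives 1%; the step between them was no change at the digits printed from compound 1 to compound 2 (within the scatter). Compound 2 therefore stands level with compound 1, both close to no inhibition. Compound 3 `CC(C)(C)Cc1c(-c2c(F)cccc2F)sc(N)c1C(=O)c1ccc(Cl)cc1` differs from compound 2 as follows: 2,6-difluorophenyl in place of 2,4-difluorophenyl on an aromatic carbon. Among the measured compounds shown here, the one measured step, exchanging a whole aryl group, was flat, so this smaller rearrangement is expected to give no movement beyond the scatter, no change at the digits printed from compound 2 to compound 3 (within the scatter). Compound 3 is estimated at 1%, in a range from -8% to 10%.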

Compound 3, a percentage reported as inhibition, at one concentration (the size of the read-out at that concentration, not a potency): 1%
For compound 3 middle estimate and measured number coincide at the digits printed; the range from low to high includes it.
By their numbers in this assay, from the lowest: compounds 1, 2 and 3 (each within the scatter of the next).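

In this assay, rearranging the fluorines on the phenyl ring gives no change at the digits printed from compound 2 to compound 3 (within the scatter), and exchanging pyridin-2-yl for 2,6-difluorophenyl gives no change at the digits printed from compound 1 to compound 3 (within the scatter). At this position, next to the ring sulfur, all three aryl groups therefore read alike, close to no inhibition, so neither the fluorine arrangement nor the exchange of the ring separates them. No measurement at hand offers an explanation for this flat result. Still open, from the compounds shown here alone, is whether an amine, a carboxylic acid or a longer chain here would raise the reading, and whether replacing the neopentyl group would.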